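This account rests on a few compounds, and the source may have more. Where it says the series, first, only, none or still open, it means among the compounds named here.

Measured in an ADME assay on microsomes from liver (Mus musculus) for metabolic stability; on this read-out higher numbers stand for a longer-lived compound and lower numbers for a shorter-lived compound:
Compound 1 (`CCCO[C@@H]1O[C@H](CNC(=O)c2ccc(S(N)(=O)=O)cc2)[C@H](O)[C@H](O)[C@H]1O`): 66.4 h
Compound 2 (`CCO[C@@H]1O[C@H](CNC(=O)c2ccc(S(N)(=O)=O)cc2)[C@@H](O)[C@H](O)[C@@H]1O`): 61.6 h

The values of compound 2 and compound 1 lie within the scatter of each other, so neither stands apart. Compound 3 (`CCCO[C@@H]1O[C@H](CNC(=O)c2ccc(S(N)(=O)=O)cc2)[C@@H](O)[C@H](O)[C@@H]1O`) is compound 2 with one change: methyl in place of hydrogen on a saturated chain carbon, two bonds along the chain from an oxygen on a saturated carbon, which reads as ethoxy to propoxy. Within the data shown here, no measured pair shows the size of this change in this assay. Compound 1 also carries propoxy, though it differs elsewhere, and gives 66.4 h, so no step beyond the scatter is expected in either direction. The estimated 1.0-fold higher number from compound 2 to compound 3 (0.01 log units; within the scatter) is small. For compound 3 the expected half-life is 63 h, with an estimated range of 35 h to 110 h.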

Compound 3, half-life: 64.5 h
Estimate against measurement, compound 3: 1.0-fold (0.01 log units) below, and the stated range covers the measured number.
By their numbers in this assay, from the lowest: compounds 2, 3 and 1 (each within the scatter of the next).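

In this assay, the change from ethoxy to propoxy gives a 1.0-fold higher number from compound 2 to compound 3 (0.02 log units; within the scatter), the first measured size for this change on a saturated chain carbon, two bonds along the chain from an oxygen on a saturated carbon. With propoxy held in place, the two ring stereocentres give a 1.0-fold lower number from compound 1 to compound 3 (0.01 log units; within the scatter), so this step reads configuration alone: the fact that compounds 1 and 3 differ only in the configuration as drawn

Going by these compounds, whether a longer chain such as butoxy, or an amine on that chain, would give a step beyond the scatter remains open. So does the size of the ethoxy to propoxy change in the configuration of compound 1.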